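A 3-chlorophenyl swap on the carbonyl of compound 2

A few compounds are considered here, and "the series" means these few. Any claim that something is new, unique, unknown or untested is made for them only; others in the source may bear on it.

Measured in a functional assay on U-251 cells (Homo sapiens) for antiproliferative activity, read by MTT assay, with a stated time of 72 h; on this read-out higher numbers stand for weaker inhibition and lower numbers for stronger inhibition:
- Compound 1 `O=C(Nc1ccc(Cl)c(-c2nnc3c(Cl)cccn23)c1)c1ccc(C(F)(F)F)cc1Cl`: > 100000 nM (a limit, not a number)
- Compound 2 `O=C(Nc1ccc(Cl)c(-c2nnc3c(Cl)cccn23)c1)c1ccccn1`: 79000 nM

Among the measured compounds shown here, compound 2, at 79000 nM, holds the only actual number so far in this assay. The other reading belongs to compound 1, and its > 100000 nM is a limit.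

Compound 3 `O=C(Nc1ccc(Cl)c(-c2nnc3c(Cl)cccn23)c1)c1cccc(Cl)c1` keeps the shared core of compound 2 and has 3-chlorophenyl in place of pyridin-2-yl on a carbonyl carbon, the one bonded to the amide-type nitrogen: 3-chlorophenyl in place of pyridin-2-yl on a carbonyl carbon. For the measured compounds named here, no measured pair isolates this change, so any expectation rests on little. The nearest guide is compound 1, which also has a chlorine-bearing, carbon-only aromatic ring on that carbonyl carbon. Its > 100000 nM is a limit, and it offers no sign of a large gain. The expected result is therefore a small move at most, with a 1.3-fold lower number from compound 2 to compound 3 (0.12 log units; within the scatter) estimated to stay within the usual scatter of this assay. A reading that reaches only the limit also remains possible. For compound 3 the expected value is 60000 nM, with an estimated range of 15000 nM to 100000 nM.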

Compound 3, half-maximal inhibitory concentration: 43100 nM
Compound 3: the middle estimate sits 1.4-fold (0.14 log units) above what was measured, and the stated range covers the measured number.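

In this assay, 3-chlorophenyl in place of pyridin-2-yl on the carbonyl carbon gives a 1.8-fold lower number from compound 2 to compound 3 (0.26 log units; within the scatter), so the two readings cannot be told apart. This first measured pair at the position shows that the ring nitrogen with its hydrogen-bond acceptor can leave and a chlorine can enter without a step beyond the scatter, and that a ring of carbon only on that carbonyl carbon can give an actual number, as compound 3 does with 43100 nM. Compound 1 also carries a chlorine-bearing ring of carbon only there, but its reading remains a limit and not a number: the limit of > 100000 nM in this assay, at which 1 of the 3 values shown sits.

The step changes the ring nitrogen and the chlorine together, so the compounds shown cannot separate the two; plain phenyl or 4-chlorophenyl on the same carbonyl carbon would bear on that. Also open, going by these compounds, is whether anything at this place moves the number beyond the scatter, for instance a ring carrying an amine or a carboxylic acid, or a butyl chain in place of the ring.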